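Adding a Chloro Group to Compound 1

This account rests on a few compounds, and the source may have more. Where it says the series, first, only, none or still open, it means among the compounds named here.

Compound 1 `Cn1cc(SCC(=O)Nc2ccccc2Cl)c2ccccc21` was tested in an ADME assay on HEK-293T cells (Homo sapiens) for cytotoxicity, read by CCK-8 assay, with a stated time of 48 h; on this read-out lower numbers stand for higher toxicity in this test and higher numbers for lower toxicity in this test. In this assay compound 1 gives > 100000 nM, which is a limit of the assay rather than a measured number. Compound 2 `Cn1cc(SCC(=O)Nc2c(Cl)cccc2Cl)c2ccccc21` gives > 100000 nM, again only a limit. The step that the two limits leave unreadable from compound 1 to compound 2 therefore cannot be sized, since (the limit of > 100000 nM in this assay, at which 2 of the 2 values shown sit). Compound 3 `Cn1cc(SCC(=O)Nc2cc(Cl)ccc2Cl)c2ccccc21` differs from compound 1 by chloro in place of hydrogen on an aromatic carbon. Going by the values given here, the only comparable measured step, from compound 1 to compound 2, is unreadable, so no guidance on direction or size exists. For compound 3 the expected step is a step that the limit leaves unreadable from compound 1 to compound 3. Compound 3 is estimated at 150000 nM, within 80000 nM to 300000 nM, most likely another limit.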

Compound 3, half-maximal cytotoxic concentration: > 100000 nM
Compound 3: only a limit was reported; the forecaster's own chance of this, stated with the estimate: 85%; the middle value does not contradict the limit.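

No step from compound 1 to compound 3 can be read, because both results are only limits of the assay: the limit of > 100000 nM in this assay, at which 3 of the 3 values shown sit.

The compounds shown leave open whether adding a chloro group changes the result in this assay at all, and in which direction.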